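The compounds below may be only part of what the source reports. "The series", "measured", "known", "first", "only" and "open" are said of these compounds alone.

Measured so far:
Compound 1 `COc1ccc(NC(=O)Cn2nc(-c3ccccc3)c3ccccc3c2=O)cc1`: > 100000000 nM
Compound 2 `O=C(Cn1nc(Cc2ccccc2)c2ccccc2c1=O)Nc1ccccc1`: 66000 nM

Only two results are available from a functional assay on HepG2 cells (Homo sapiens) for antiproliferative activity, read by sulforhodamine B assay, with a stated time of 72 h; on this read-out higher numbers stand for weaker inhibition and lower numbers for stronger inhibition. For compound 1, > 100000000 nM is a limit of the assay and not a number. For the measured compounds named here, that makes compound 2, at 66000 nM, the only true number in the set, so it has no measured neighbour to be ranked against.

The next compound is compound 3 `COc1ccc(NC(=O)Cn2nc(Cc3ccccc3)c3ccccc3c2=O)cc1`, which is built from compound 2 by a single edit: methoxy in place of hydrogen on an aromatic carbon. A methoxy takes the place of a hydrogen on an aromatic carbon, para to a large group, so the phenyl becomes 4-methoxyphenyl.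

Going by the values given here, no measured step of this kind exists in the set, so the size of the change can only be judged from compound 2 at 66000 nM. In this assay, no step beyond the scatter is expected, and the expected result is a 1.2-fold higher number from compound 2 to compound 3 (0.08 log units; within the scatter). Compound 3 is estimated at 80000 nM, with an expected range of 25000 nM to 250000 nM.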

Compound 3, half-maximal inhibitory concentration: 69000 nM
Estimate against measurement, compound 3: 1.2-fold (0.06 log units) above, within the range that was stated.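

In this assay, the change from phenyl to 4-methoxyphenyl gives a 1.0-fold higher number from compound 2 to compound 3 (0.02 log units; within the scatter), so in this pair a methoxy at this place, para to a large group, leaves the result within the usual variation between repeat measurements. The other comparison keeps the methoxy and alters only the group on the core, where benzyl in place of phenyl gives an at least 1400-fold lower number from compound 1 to compound 3 (3.16 log units; beyond the scatter), so in these compounds that group counts for far more than the methoxy does. The value of compound 1 is a limit of the assay and not a number, which means that this step gives only the smallest possible size of the difference: the limit of > 100000000 nM in this assay, at which 1 of the 3 values shown sits.

From the compounds shown here alone, it remains open whether a different group at the same place, such as an amine or a carboxylic acid, would also leave the result unchanged, or whether the methoxy is simply one of the few groups that do. Going by these compounds, it is also open how a longer chain between the core and the phenyl ring, such as a two-carbon ethylene link, would compare with benzyl.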